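Methyl for hydrogen on the five-membered ring: series notes

The source may hold more compounds than are shown below. What is called first, only, known or untested is meant among the compounds shown, and "the series" means these compounds.

Compound 1 `Cc1ccc(CNC(=O)c2cccc(C(C)Oc3cccnc3Nc3nccs3)c2)cc1` is the reference; in a functional assay on HCC78 cells (Homo sapiens) for antiproliferative activity, read by MTT assay, with a stated time of 48 h (on this read-out lower numbers stand for stronger inhibition and higher numbers for weaker inhibition), compound 1 gives 27100 nM. Compound 2 `Cc1ccc(CNC(=O)c2cccc(C(C)Oc3cccnc3Nc3ncc(C)s3)c2)cc1` carries the change methyl in place of hydrogen on an aromatic carbon and in this assay compound 2 gives 14800 nM; the step is a 1.8-fold lower number from compound 1 to compound 2 (0.26 log units; within the scatter). Compound 3 `Cc1ccc(CNC(=O)c2cccc(C(C)Oc3ccnc(Nc4cnn(C)c4)c3)c2)cc1` rests on a different core, and the difference between the two cores is not broken down here. In this assay compound 3 gives 8900 nM; its gap to compound 1 is beyond the scatter, its gap to compound 2 within it. Compound 4 `Cc1ccc(CNC(=O)c2cccc(C(C)Oc3ccnc(Nc4cn(C)nc4C)c3)c2)cc1` is not yet measured and differs from compound 3 by methyl in place of hydrogen on an aromatic carbon. This is the same kind of change as that from compound 1 to compound 2, not the same: there the methyl entered a five-membered aromatic ring with 1 nitrogen and 1 sulfur, next to the ring sulfur, two ring bonds from the ring nitrogen and from the ring atom that bears a large group; here it enters a five-membered aromatic ring with 2 nitrogen, next to the ring nitrogen, next to the ring atom that bears a large group, two ring bonds from the ring nitrogen and from the ring atom that bears a methyl group. For the measured compounds named here, the expected step is a 1.3-fold lower number from compound 3 to compound 4 (0.10 log units; within the scatter), set beside the measured one, because a 1.8-fold lower number from compound 1 to compound 2 (0.26 log units; within the scatter) stayed within the scatter and no other pair speaks to the change. Compound 4 is therefore estimated at 7000 nM, with a range from 3000 nM to 17000 nM.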

Compound 4, half-maximal inhibitory concentration: 17500 nM
Compound 4: middle estimate off by 2.5-fold (0.40 log units), on the low side; measured number above the stated range.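

In this assay the step on the core of compound 3 is a 2.0-fold higher number from compound 3 to compound 4 (0.29 log units; within the scatter), and taken alone it does not separate the methyl from repeat scatter. Set side by side, the two steps do not agree, so methyl in place of hydrogen on an aromatic carbon cannot be carried as one fixed increment from the core of compound 1 to the core of compound 3: the same change on two cores in this assay, a 1.8-fold lower number (0.26 log units; within the scatter) from compound 1 to compound 2 and a 2.0-fold higher number (0.29 log units; within the scatter) from compound 3 to compound 4, 3.6-fold (0.56 log units) apart, beyond the scatter of two such steps. This does not show what sets the two steps apart, since the pairs differ both in the five-membered ring that takes the methyl and in the rest of the core, and two pairs give no rule for any further core.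

The compounds shown leave open what a group other than methyl, such as ethyl, methoxy or an amine, would do at the same place on the 1-methyl-1H-pyrazol-4-yl ring. They also leave open whether the disagreement between the two steps would hold on a third core.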